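Swapping the aryl on the ring nitrogen: from methyl to bromo-fluoro

The compounds below may be only part of what the source reports. "The series", "measured", "known", "first", "only" and "open" are said of these compounds alone.

Three compounds share one core and differ only in the aryl group attached to an aromatic nitrogen. Compound 1 `CCNC(=O)c1cc(Oc2ccc(NC(=O)c3nn(-c4cccc(F)c4)c(=O)cc3C)cc2)ccn1` gives 7410 nM in a functional assay on A549 cells (Homo sapiens) for antiproliferative activity, read by MTT assay, with a stated time of 72 h; a higher number here means a weaker inhibitor, a lower number a stronger inhibitor. Compound 2 `CCNC(=O)c1cc(Oc2ccc(NC(=O)c3nn(-c4ccccc4OC(F)(F)F)c(=O)cc3C)cc2)ccn1` gives 5280 nM. Compound 3 `CCNC(=O)c1cc(Oc2ccc(NC(=O)c3nn(-c4ccc(C)cc4)c(=O)cc3C)cc2)ccn1` gives 11600 nM, the highest of the three numbers shown; its nearest neighbour is compound 1, since a 1.6-fold higher number from compound 1 to compound 3 (0.19 log units; within the scatter), and its furthest is compound 2, since a 2.2-fold higher number from compound 2 to compound 3 (0.34 log units; beyond the scatter).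

Compound 4 `CCNC(=O)c1cc(Oc2ccc(NC(=O)c3nn(-c4ccc(Br)cc4F)c(=O)cc3C)cc2)ccn1` has not yet been measured. Its change from compound 3 is 4-bromo-2-fluorophenyl in place of 4-methylphenyl on an aromatic nitrogen, so again only the aryl group on the aromatic nitrogen is altered. The three measured steps all concern this same aryl position and were small: a 1.4-fold lower number from compound 1 to compound 2 (0.15 log units; within the scatter), a 1.6-fold higher number from compound 1 to compound 3 (0.19 log units; within the scatter) and a 2.2-fold higher number from compound 2 to compound 3 (0.34 log units; beyond the scatter). The two aryl groups carrying fluorine or trifluoromethoxy gave lower numbers than 4-methylphenyl, though only compound 2 stands beyond the scatter from compound 3. A 4-bromo-2-fluorophenyl group is therefore expected to give compound 4 a number similar to or somewhat lower than that of compound 3, with the expected step being a 1.8-fold lower number from compound 3 to compound 4 (0.25 log units; within the scatter). The estimate for compound 4 is 6500 nM, expected to fall between 3000 nM and 14000 nM.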

Compound 4, half-maximal inhibitory concentration: 34500 nM
Compound 4: middle estimate off by 5.3-fold (0.72 log units), on the low side, and the stated range ends below it.
By their numbers in this assay, from the lowest: compounds 2, 1 and 3 (each within the scatter of the next, the first and the last beyond it); then compound 4.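

In this assay, among the compounds shown here, this aryl position proves able to shift the number further than the earlier compounds showed, with a 3.0-fold higher number from compound 3 to compound 4 (0.47 log units; beyond the scatter) and larger gaps still in a 4.7-fold higher number from compound 1 to compound 4 (0.67 log units; beyond the scatter) and in a 6.5-fold higher number from compound 2 to compound 4 (0.82 log units; beyond the scatter). Compound 4 is thus the weakest inhibitor of the four, and halogen on the aryl group does not go with a lower number across this set: compound 1 and compound 2 carry fluorine and stand lowest, while compound 4 carries fluorine and bromine and stands highest. Nothing measured here on these compounds accounts for the rise in the number.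

The entering group differs from 4-methylphenyl in two ways at once, so the compounds shown cannot separate the part played by the bromine from that of the fluorine, a question that the simpler 4-bromophenyl and 2-fluorophenyl groups would address. Also open, as far as these compounds go, is whether an amine or a carboxylic acid on this aryl group would bring the number down, or whether a benzyl group in place of the aryl would change it at all.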